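Swapping the Aromatic Group on a Ring Nitrogen

The source may report more compounds than this note shows. Statements on the series, on what has been measured and on what is new or still open speak of the compounds shown alone.

Compound 1 `O/N=C(\CCN1CCN(c2ccccn2)CC1)c1ccccc1` was tested in a functional assay on HEK293 cells with D(4) dopamine receptor (Homo sapiens) as the target, read by FLIPR (on this read-out higher numbers stand for larger maximal responses and lower numbers for smaller maximal responses), where compound 1 gives 70%. Compound 2 `C=CCO/N=C(\CCN1CCN(c2ccccn2)CC1)c1ccccc1`, which carries an allyl in place of a hydrogen on an oxygen, gives 69% in this assay. Compound 1 stands at the top of these two numbers, but the step of a number 1 percentage points lower from compound 1 to compound 2 (within the scatter) lies within the scatter, so no real difference between the two is shown. Compound 3 `O/N=C(\CCN1CCN(c2ncccn2)CC1)c1ccccc1` differs from compound 1 by pyrimidin-2-yl in place of pyridin-2-yl on an amine nitrogen in a ring. Going by the values given here, the single measured step concerns an oxygen, not the amine nitrogen in a ring, so no measured step bears directly on this change; the only guide is that one small change elsewhere left the response unmoved. In this assay the expected step is a number 5 percentage points lower from compound 1 to compound 3 (within the scatter), within the scatter. Compound 3 is therefore estimated to give 65%, in a range from 45% to 85%.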

Compound 3, largest response reached (reported as efficacy), in percent of the reference or control that the assay uses: 49%
For compound 3 the middle estimate is 16 percentage points above the measured one, and the stated range covers the measured number.
By their numbers in this assay, from the lowest: compound 3; then compounds 2 and 1 (each within the scatter of the next).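

The position on the amine nitrogen in a ring is not indifferent to its aromatic group: in this assay, pyrimidin-2-yl in place of pyridin-2-yl gives a number 21 percentage points lower from compound 1 to compound 3 (beyond the scatter), whereas the allyl on the oxygen gave a step within the scatter. This swap leaves the count of heavy atoms unchanged, exchanging one ring carbon for a nitrogen and adding one hydrogen-bond acceptor, so even a one-atom change in this ring can shift the maximal response. Nothing measured here explains why the response shifts with this swap.

Going by these compounds, it remains open whether a plain phenyl or a pyrazin-2-yl on the same ring nitrogen would stay close to compound 1 or fall further. On these data alone, it also remains open whether adding the allyl to the oxygen of compound 3 would leave its response unmoved.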